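Compound 3 to compound 4: a change on the amide

The compounds below may be only part of what the source reports. "The series", "measured", "known", "first", "only" and "open" are said of these compounds alone.

In a functional assay on MDA-MB-435 cells (Homo sapiens) for cytotoxicity, read by MTT assay, with a stated time of 72 h (on this read-out higher numbers stand for weaker inhibition and lower numbers for stronger inhibition), compound 3 `C[C@H](NC(=O)c1nc(Br)c2cccnc2c1N[C@H]1CC[C@H](N)CC1)c1ccc(F)cc1` gives > 10000 nM as a limit and not a number. Compound 1 `N[C@H]1CC[C@H](Nc2c(C(=O)NCc3ccco3)nc(Br)c3cccnc23)CC1` gives > 10000 nM as a limit too. Compound 2 `N[C@H]1CC[C@H](Nc2c(C(=O)NCc3ccc(Cl)cc3Cl)nc(Br)c3cccnc23)CC1` gives 5800 nM as a measured number.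

Compound 4 `N[C@H]1CC[C@H](Nc2c(C(=O)NCc3ccc(Cl)cc3)nc(Br)c3cccnc23)CC1` carries 4-chlorobenzyl in place of 1-(4-fluorophenyl)ethyl on an amide-type nitrogen. The steps of an at least 1.7-fold lower number from compound 1 to compound 2 (0.23 log units; that floor lies within the scatter) and an at least 1.7-fold higher number from compound 2 to compound 3 (0.23 log units; that floor lies within the scatter) bear on this change, both as floors within the scatter. The 2,4-dichlorobenzyl of compound 2 at 5800 nM is the closest measured group, so no step beyond the scatter is expected in this assay for this change. The estimated step is an at least 1.2-fold lower number from compound 3 to compound 4 (0.09 log units; that floor lies within the scatter) in the direction of a lower number. A report of a limit alone is as likely as a number. Compound 4 is expected at 8000 nM with an estimated range from 3500 nM to 15000 nM as its two ends.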

Compound 4, half-maximal inhibitory concentration: 1000 nM
Compound 4: middle estimate off by 8.0-fold (0.90 log units), on the high side; the measured number lies below the stated range.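

In this assay, the group on the amide-type nitrogen now moves the read-out beyond the scatter, which the earlier floors did not show: an at least 10-fold lower number from compound 3 to compound 4 (1.00 log units; beyond the scatter), and an at least 10-fold lower number from compound 1 to compound 4 (1.00 log units; beyond the scatter). The second chloro of 2,4-dichlorobenzyl also matters, since hydrogen in its place gives a 5.8-fold lower number from compound 2 to compound 4 (0.76 log units; beyond the scatter). The first two steps are floors only: the limit of > 10000 nM in this assay, at which 2 of the 4 values shown sit.

The step from compound 3 swaps fluoro for chloro and drops the branch at once, so the two changes remain unseparated. A 4-fluorobenzyl or 1-(4-chlorophenyl)ethyl group on the same nitrogen would part them.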